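This account rests on a few compounds, and the source may have more. Where it says the series, first, only, none or still open, it means among the compounds named here.

Of the compounds shown here, three sharing one core have been measured in an assay for binding affinity to dual specificity mitogen-activated protein kinase kinase 4 (Homo sapiens), read by KINOMEscan, tested at 100 nM; a lower number here means a stronger effect, a higher number a weaker effect of the compound at the concentration tested. Compound 1 `CCCS(=O)(=O)Nc1ccc(F)c(C(=O)c2n[nH]c3ncc(-c4ccccc4)cc23)c1F` gives 2.4%. Compound 2 `CCCS(=O)(=O)Nc1ccc(F)c(C(=O)c2n[nH]c3ncc(-c4ccc(Cl)cc4Cl)cc23)c1F` gives 22%. Compound 3 `CCCS(=O)(=O)Nc1ccc(F)c(C(=O)c2n[nH]c3ncc(-c4ccc(Cl)c(Cl)c4)cc23)c1F` gives 45%, the highest of the three numbers; compound 2 stands nearest to it and compound 1 furthest from it, both gaps being beyond the scatter. Every measured step changes the aryl group on the same aromatic carbon of the core: a number 19.6 percentage points higher from compound 1 to compound 2 (beyond the scatter), a number 42.6 percentage points higher from compound 1 to compound 3 (beyond the scatter), and a number 23 percentage points higher from compound 2 to compound 3 (beyond the scatter).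

Compound 4 `CCCS(=O)(=O)Nc1ccc(F)c(C(=O)c2n[nH]c3ncc(-c4ccc(S(=O)(=O)NC)cc4)cc23)c1F` differs from compound 3 at that same place: 4-(methylsulfamoyl)phenyl in place of 3,4-dichlorophenyl on an aromatic carbon. Among the measured compounds shown here, no measured step swaps a dichlorophenyl for a 4-(methylsulfamoyl)phenyl, so none bears on it directly. For the measured compounds named here, the three known steps show only that exchanging this group shifts the read-out by modest to large amounts, with the unsubstituted phenyl of compound 1 giving the lowest number and the dichlorophenyls giving higher ones. A move toward lower numbers is thus judged somewhat more likely than a further rise, but with wide uncertainty, and the step is estimated as a number 20 percentage points lower from compound 3 to compound 4 (beyond the scatter). Compound 4 is expected to give 25% in this assay, within a range from 3% to 70%.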

Compound 4, a percentage reported as activity, at one concentration (the size of the read-out at that concentration, not a potency): 1.2%
For compound 4 the middle estimate is 23.8 percentage points above the measured one; measured number outside the range, below it.
By their numbers in this assay, from the lowest: compounds 4 and 1 (each within the scatter of the next); then compound 2; then compound 3.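

In this assay, the dichlorophenyl groups had raised the number, but a substituted phenyl at this carbon does not have to do so: the change to 4-(methylsulfamoyl)phenyl gives a number 43.8 percentage points lower from compound 3 to compound 4 (beyond the scatter) and a number 20.8 percentage points lower from compound 2 to compound 4 (beyond the scatter) in the same read-out. Set against the unsubstituted phenyl, the methylsulfamoyl group gives a number 1.2 percentage points lower from compound 1 to compound 4 (within the scatter) so this carbon of the core carries a group with more heavy atoms than either dichlorophenyl without any change beyond the scatter from compound 1. No evidence is at hand on why these groups part so widely in this read-out.

As far as these compounds go, with only one concentration behind the read-out, compound 1 and compound 4 are not told apart, and whether a real difference in affinity lies between them stays open. Also open, from the compounds shown here alone, is whether the methylsulfamoyl group keeps this result at another place on the phenyl ring, and what a single chlorine, a carboxylic acid or a morpholine on that ring would do.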